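Widening a Saturated Ring on the Shared Core

The compounds below may be only part of what the source reports. "The series", "measured", "known", "first", "only" and "open" are said of these compounds alone.

Among the measured compounds shown here, compound 1 `CN1CCN(CC(=O)NC2CC3(N4CCCC4)CC(c4ccccc4)C2C(c2ccccc2)C3)CC1` is one of three compounds measured in an ADME assay on L6 cells (Rattus norvegicus) for cytotoxicity, read by resazurin assay, with a stated time of 72 h (a higher number here means a weaker inhibitor, a lower number a stronger inhibitor), where compound 1 gives 50200 nM. Compound 2 `NCC(=O)OC1CC2(N3CCCC3)CC(c3ccccc3)C1C(c1ccccc1)C2` gives 42900 nM in this assay, and compound 3 `CN1CCN(CCC(=O)NC2CC3(N4CCCC4)CC(c4ccccc4)C2C(c2ccccc2)C3)CC1` gives 86700 nM. Compound 1 stands second highest of the three numbers: nearest to compound 2, as a 1.2-fold lower number from compound 1 to compound 2 (0.07 log units; within the scatter) shows, and furthest from compound 3, as a 1.7-fold higher number from compound 1 to compound 3 (0.24 log units; within the scatter) shows. Both of those steps changed a group on a saturated ring carbon and both stayed within the scatter, while a 2.0-fold higher number from compound 2 to compound 3 (0.31 log units; beyond the scatter) is modest.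

Compound 4 `CN1CCN(CC(=O)NC2CC3(N4CCCCC4)CC(c4ccccc4)C2C(c2ccccc2)C3)CC1` differs from compound 1 in another part of the shared core: piperidin-1-yl in place of pyrrolidin-1-yl on a saturated ring carbon. For the measured compounds named here, none of the measured steps touches the pyrrolidin-1-yl group, since all three measured compounds carry it unchanged, so the measured steps give no direct guide to this change. The expectation is therefore a step of a 1.0-fold lower number from compound 1 to compound 4 (0.00 log units; within the scatter), not beyond the scatter. Compound 4 is estimated to give 50000 nM in this assay, with a range from 25000 nM to 100000 nM.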

Compound 4, half-maximal inhibitory concentration: 57500 nM
Estimate against measurement, compound 4: 1.2-fold (0.06 log units) below; measured number inside the range.
By their numbers in this assay, from the lowest: compounds 2, 1, 4 and 3 (each within the scatter of the next, the first and the last beyond it).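

The pyrrolidin-1-yl group is the same in compound 1, compound 2 and compound 3, so only this result speaks to the position it occupies. In this assay, the six-membered piperidin-1-yl ring in place of the five-membered pyrrolidin-1-yl ring gives a 1.1-fold higher number from compound 1 to compound 4 (0.06 log units; within the scatter), so this saturated ring carbon accepts the larger ring with no shift that stands out from repeat measurements. Nothing available here offers a measured explanation for this result.

From the compounds shown here alone, only these two rings can be compared at this position, so it stays open whether an open-chain dimethylamino group or a morpholin-4-yl ring, which carries an oxygen atom, would leave the number as little changed. Going by these compounds, it is also open whether the same swap would behave alike alongside the ((aminomethyl)carbonyl)oxy group of compound 2.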